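The compounds below may be only part of what the source reports. "The series", "measured", "known", "first", "only" and "open" are said of these compounds alone.

Compound 3 `O=c1cc(-c2ccccc2)oc2cc(OCCCCNc3nc4ccc(F)cc4s3)cc(O)c12` is one of three measured analogues that share a core and differ only in the group on the fused ring. In a functional assay on HeLa cells (Homo sapiens) for cytotoxicity, read by sulforhodamine B assay, with a stated time of 48 h (a higher number here means a weaker inhibitor, a lower number a stronger inhibitor), compound 3 gives 5.03 ug/mL. Compound 1 `Cc1ccc2nc(NCCCCOc3cc(O)c4c(=O)cc(-c5ccccc5)oc4c3)sc2c1` gives 6.56 ug/mL, and compound 2 `O=c1cc(-c2ccccc2)oc2cc(OCCCCNc3nc4ccc([N+](=O)[O-])cc4s3)cc(O)c12` gives 6.44 ug/mL. The three numbers lie close together: a 1.0-fold lower number from compound 1 to compound 2 (0.01 log units; within the scatter), a 1.3-fold lower number from compound 1 to compound 3 (0.12 log units; within the scatter) and a 1.3-fold lower number from compound 2 to compound 3 (0.11 log units; within the scatter) are each within the scatter, so compound 3 cannot be set apart from compound 1 or compound 2 in this assay.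

Compound 4 `O=C(O)c1ccc2nc(NCCCCOc3cc(O)c4c(=O)cc(-c5ccccc5)oc4c3)sc2c1` differs from compound 3 by carboxy in place of fluoro on an aromatic carbon. For the measured compounds named here, no measured step involves a carboxy group, so its effect is unknown here. All three measured steps, however, swap groups at this same position and all stay within the scatter, which gives no reason to expect a step beyond the scatter in this assay in either direction. Compound 4 is therefore expected to give 6.5 ug/mL, between 3.5 ug/mL and 12 ug/mL, an expected step of a 1.3-fold higher number from compound 3 to compound 4 (0.11 log units; within the scatter).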

Compound 4, half-maximal inhibitory concentration: 8.43 ug/mL
Compound 4: the middle estimate sits 1.3-fold (0.11 log units) below what was measured; the measured number falls inside the stated range.
By their numbers in this assay, from the lowest: compounds 3, 2, 1 and 4 (each within the scatter of the next).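

Replacing fluoro with carboxy adds a hydrogen-bond donor and a hydrogen-bond acceptor, yet in this assay the result is still small (a 1.7-fold higher number from compound 3 to compound 4 (0.22 log units; within the scatter)). The carboxy compound also stays close to the other two analogues (a 1.3-fold higher number from compound 2 to compound 4 (0.12 log units; within the scatter)) and (a 1.3-fold higher number from compound 1 to compound 4 (0.11 log units; within the scatter)). This position has now taken methyl, nitro, fluoro and carboxy without any step beyond the scatter, so in this assay these four groups cannot be told apart, and nothing available explains why.

Going by these compounds, whether an amine or a methyl ester at this position would give a step beyond the scatter remains open. So does whether a longer chain in place of the present linker would change the number in this assay.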